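The compounds below may be only part of what the source reports. "The series", "measured", "known", "first", "only" and "open" are said of these compounds alone.

Measured so far in an assay for inhibition of NAD-dependent protein deacylase sirtuin-6 (Homo sapiens), read by HPLC, with stated times of 15 min and 1 h, tested at 333 uM; on this read-out higher numbers stand for more inhibition at the one concentration tested (going by the name of the read-out) and lower numbers for less inhibition:

compound 1, `CCNC(=O)CCCSC[C@H](NC(=O)OCc1ccccc1)C(=O)Nc1ccccc1`: 15%
compound 2, `CCCCCCCCCCNC(=O)CCCSC[C@H](NC(=O)OCc1ccccc1)C(=O)Nc1ccccc1`: 28%
compound 3, `O=C(O)CCNC(=O)CCCSC[C@H](NC(=O)OCc1ccccc1)C(=O)Nc1ccccc1`: 43%

Compound 3 stands highest of the three numbers in this assay. Compound 2 is nearest, the step being a number 15 percentage points higher from compound 2 to compound 3 (beyond the scatter); compound 1 is furthest, with a number 28 percentage points higher from compound 1 to compound 3 (beyond the scatter). Both of those steps lie beyond the scatter, so the number for compound 3 is the highest of the three at the tested concentration. The step from compound 1 to compound 2 is a number 13 percentage points higher from compound 1 to compound 2 (beyond the scatter).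

Compound 4, `CNC(=O)CCCSC[C@H](NC(=O)OCc1ccccc1)C(=O)Nc1ccccc1`, has not yet been measured in this assay. Its difference from compound 3 is hydrogen in place of carboxymethyl on a saturated chain carbon bound to an amide-type nitrogen. Among the compounds with values here, the step that bears most directly on this is the one from compound 1 to compound 3, in which a carboxy group entered on a saturated chain carbon two bonds along the chain from the amide-type nitrogen and the number rose by a number 28 percentage points higher from compound 1 to compound 3 (beyond the scatter). The change to compound 4 removes the carboxymethyl group and leaves a shorter chain than compound 1 carries, so a drop of roughly that size is expected in this assay, taking compound 4 back to the region of compound 1.

Compound 4 is therefore estimated to give 16% in this assay, within a range of 4% to 30%, which corresponds to an expected step of a number 27 percentage points lower from compound 3 to compound 4 (beyond the scatter).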

Compound 4, a percentage reported as inhibition, at one concentration (the size of the read-out at that concentration, not a potency): "not active" (no number reported)
The entry for compound 4 holds no number, and the estimate cannot be compared.
By their numbers in this assay, from the lowest: compound 1; then compound 2; then compound 3.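

Within the data shown here, compound 4 is entered as "not active" in this assay, with no number, so no step from it to compound 1, compound 2 or compound 3 can be read. No measured evidence bears on this result. The compounds shown leave open whether compound 4 lies close to compound 1 or clearly lower in this read-out.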